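A few compounds are considered here, and "the series" means these few. Any claim that something is new, unique, unknown or untested is made for them only; others in the source may bear on it.

Working notes on the series, read in an ADME assay on Huh-7 cells (Homo sapiens) for cytotoxicity, read by MTT assay; a lower number here means a stronger inhibitor, a higher number a weaker inhibitor. Compound 1 (`COc1ccc(Oc2ccc(N3CC(=O)N([C@@H](CC4CCN(C(=O)C(C)C)CC4)c4nc5ccc(F)cc5n4C)C3=O)cc2)cc1`) gives > 100000 nM, which is a limit of the assay and not a number. Compound 2 (`Cc1ccc2nc([C@H](CC3CCN(C(=O)C(C)C)CC3)N3C(=O)CN(c4ccc(Oc5ccc(F)cc5)cc4)C3=O)n(C)c2c1`) gives > 100000 nM, which is likewise a limit and not a number. Compound 2 therefore has no numeric standing, and no order can be drawn between it and compound 1. The whole record so far is the limit of > 100000 nM in this assay, at which 2 of the 2 values shown sit.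

Compound 3 (`COc1ccc(Oc2ccc(N3CC(=O)N([C@@H](CC4CCN(C(=O)C(C)C)CC4)c4nc5ccc(C)cc5n4C)C3=O)cc2)cc1`) differs from compound 2 by a single change: methoxy in place of fluoro on an aromatic carbon. In short, methoxy stands in place of fluoro on an aromatic carbon, para to a large group, turning 4-fluorophenoxy into 4-methoxyphenoxy. Among the compounds with values here, no step between measured compounds is available to size this change, so the expectation rests on the shared limit alone. The estimated step is a number no higher from compound 2 to compound 3 (the limit leaves the size open), which is expected to be none beyond the usual scatter, and another report at the limit is the likeliest outcome in this assay. For compound 3 the expected value is 100000 nM, with an estimated range of 60000 nM to 170000 nM.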

Compound 3, half-maximal inhibitory concentration: > 100000 nM
Compound 3 gave a limit, no number; the forecaster's own chance of this, stated with the estimate: 85%; the middle value sits exactly at the limit.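

Within the data shown here, compound 3 also gives only a limit in this assay, so no step linking it to compound 1 or compound 2 can be read, and all three compounds stand together at: the limit of > 100000 nM in this assay, at which 3 of the 3 values shown sit.

Left open is where any of the three compounds would read as a number, and so whether methoxy in place of fluoro or methyl in place of fluoro moves the reading at all.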